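A few compounds are considered here, and "the series" means these few. Any claim that something is new, unique, unknown or untested is made for them only; others in the source may bear on it.

Measured so far in a functional assay on HeLa cells (Homo sapiens) for cytotoxicity, read by MTT assay, with a stated time of 72 h; on this read-out higher numbers stand for weaker inhibition and lower numbers for stronger inhibition:
- compound 1 `N#Cc1ccc(/C=C/C(=O)Nc2cc3c(Nc4ccc(F)c(Cl)c4)ncnc3cc2O[C@H]2CCOC2)cc1`: "not determined" (no result reported)
- compound 2 `COc1ccc(/C=C/C(=O)Nc2cc3c(Nc4ccc(F)c(Cl)c4)ncnc3cc2O[C@H]2CCOC2)c(OC)c1OC`: 4830 nM
- compound 3 `O=C(/C=C/c1ccccc1[N+](=O)[O-])Nc1cc2c(Nc3ccc(F)c(Cl)c3)ncnc2cc1O[C@H]1CCOC1`: 29600 nM

Of the two numbers available in this assay, the higher belongs to compound 3, at 29600 nM. Compound 1 offers no number for comparison.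

Next in the series is compound 4 `O=C(/C=C/c1ccc(Br)cc1)Nc1cc2c(Nc3ccc(F)c(Cl)c3)ncnc2cc1O[C@H]1CCOC1`, which carries 4-bromophenyl in place of 2-nitrophenyl on a double-bonded chain carbon bound to a double-bonded chain carbon.

For the measured compounds named here, only one measured step bears on this change: a 6.1-fold higher number from compound 2 to compound 3 (0.79 log units; beyond the scatter). It is modest but beyond the scatter, and it was made at the same place, with 2-nitrophenyl entering in place of 2,3,4-trimethoxyphenyl. Going by the values given here, no measured compound carries 4-bromophenyl, so this single step is weak guidance. A move toward stronger inhibition is expected, smaller than that measured step. The expected change is a 2.5-fold lower number from compound 3 to compound 4 (0.39 log units; beyond the scatter). For compound 4 the estimated value is 12000 nM, with an expected range of 3500 nM to 40000 nM.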

Compound 4, half-maximal inhibitory concentration: 27500 nM
For compound 4 the middle estimate is 2.3-fold (0.36 log units) below the measured one, within the range that was stated.
By their numbers in this assay, from the lowest: compound 2; then compounds 4 and 3 (each within the scatter of the next).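

In this assay, 4-bromophenyl and 2-nitrophenyl cannot be told apart at this position: a 1.1-fold lower number from compound 3 to compound 4 (0.03 log units; within the scatter), within the scatter, even though the two groups differ in their atoms and hydrogen-bond acceptor counts. The separation of compound 2 now rests on two replacements rather than one, with a 5.7-fold higher number from compound 2 to compound 4 (0.76 log units; beyond the scatter) pointing the same way as a 6.1-fold higher number from compound 2 to compound 3 (0.79 log units; beyond the scatter), so 2,3,4-trimethoxyphenyl gives the lowest of the three numbers. No measurement at hand accounts for this result.

As far as these compounds go, it remains open whether the methoxy groups themselves, or their number, set compound 2 apart from compound 3 and compound 4. Also open, from the compounds shown here alone, is how an unsubstituted phenyl, a phenyl carrying a single methoxy group or one carrying an amine would read at this place.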